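The source may report more compounds than this note shows. Statements on the series, on what has been measured and on what is new or still open speak of the compounds shown alone.

Of the compounds shown here, three built on a shared core have been tested in a functional assay on PC-9 cells (Homo sapiens) for inhibition, read by MTT assay, with a stated time of 72 h; a higher number here means a weaker inhibitor, a lower number a stronger inhibitor. Compound 1 `Cc1cc(Nc2cc(-c3cccs3)[nH]n2)n2nc(SCc3ccc(Br)cc3)nc2n1` gives 4890 nM in this assay. Compound 2 `Cc1cc(Nc2ccn(Cc3cccc4ccccc34)n2)n2nc(SCc3ccc(Br)cc3)nc2n1` gives 5660 nM in this assay. Compound 3 `Cc1cc(Nc2cc(-c3ccccc3)[nH]n2)n2nc(SCc3ccccc3Br)nc2n1` gives 5630 nM in this assay, the second highest of the three numbers; its nearest neighbour is compound 2 and its furthest is compound 1, and both of those gaps fall within the usual scatter of repeated measurements, so the three compounds cannot be separated on these numbers.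

Compound 4 `CCCSc1nc2nc(C)cc(Nc3cc(-c4ccccc4)[nH]n3)n2n1` has not yet been measured. It differs from compound 3 in a single place: ethyl in place of 2-bromophenyl on a saturated chain carbon bound to a sulfur. For the measured compounds named here, no pair of measured compounds shows an exchange of this kind, so there is no measured step to lean on. Going by the values given here, what the three known numbers do show is that the variations among them, at the group bound to the sulfur and at the other end of the molecule, left the numbers close together. For the move to compound 4 a modest step toward a higher number is expected, at or just beyond the edge of the scatter. Compound 4 is therefore estimated to give about 8000 nM in this assay, most likely between 3500 nM and 18000 nM. That estimate corresponds to an expected step of a 1.4-fold higher number from compound 3 to compound 4 (0.15 log units; within the scatter).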

Compound 4, half-maximal inhibitory concentration: > 50000 nM
Compound 4: only a limit was reported (the forecaster's own chance of this, stated with the estimate: 10%); at least 6.2-fold (0.79 log units) between middle value and limit.
By their numbers in this assay, from the lowest: compounds 1, 3 and 2 (each within the scatter of the next). At a limit, above all of these: compound 4.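

In this assay, the exchange of 2-bromobenzyl for propyl produces an at least 8.8-fold higher number from compound 3 to compound 4 (0.94 log units; beyond the scatter), and this is the only step shown that clearly moves the number. Compounds 1, 2 and 3 all carry a bromobenzyl group at this place, so their closely grouped numbers could not reveal what happens when the group is replaced by one with no ring and far fewer heavy atoms; compound 4 shows that this place is not free to vary, since the propyl compound is clearly weaker than its 2-bromobenzyl partner, compound 3. For compound 4, the reported > 50000 nM is a limit of the assay, so the size of this step is known from one side only: the limit of > 50000 nM in this assay, at which 1 of the 4 values shown sits.

From the compounds shown here alone, it remains open whether a plain benzyl group without the bromine, or a longer chain such as hexyl, would give a number close to that of compound 3, so the loss of the ring cannot yet be told apart from the shortening of the group. It is also unknown whether propyl would have a similar effect with the thiophene ring that compound 1 carries at the other end of the molecule.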